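A few compounds are considered here, and "the series" means these few. Any claim that something is new, unique, unknown or untested is made for them only; others in the source may bear on it.

Measured so far in an ADME assay on isolated protein for inhibition of Amine oxidase [flavin-containing] B (Homo sapiens); on this read-out lower numbers stand for stronger inhibition and higher numbers for weaker inhibition:
compound 1 `C#CCNC1CCc2c(OCc3cccc(C(F)(F)F)c3)cccc21` gives 5410 nM
compound 2 `C#CCNC1CCc2c(SCCc3cccc(C)c3)cccc21` gives 4960 nM
compound 3 `C#CCNC1CCc2c(SCc3ccc(OC)cc3)cccc21` gives 3960 nM

The three numbers sit close together. Compound 2 stands between compound 1 and compound 3, and both of these pairs lie within the usual scatter of repeated measurements, so no order among the three can be read from them. Compound 4 `C#CCNC1CCc2c(SCCc3ccc(Cl)c(Cl)c3)cccc21` has not yet been measured. It differs from compound 2 in one place: 3,4-dichlorophenyl in place of 3-methylphenyl on a saturated chain carbon, two bonds along the chain from a sulfur. For the measured compounds named here, no step between measured compounds covers an exchange of this kind, so the series gives nothing to set its direction or size. With all three measured numbers so alike, the expectation in this assay is a step no larger than the scatter, in either direction. Compound 4 is therefore estimated at 4000 nM, with a range from 1500 nM to 11000 nM. The expected step of a 1.2-fold lower number from compound 2 to compound 4 (0.09 log units; within the scatter) is accordingly small.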

Compound 4, half-maximal inhibitory concentration: 2820 nM
Estimate against measurement, compound 4: 1.4-fold (0.15 log units) above; low and high end bracket the measured number.
By their numbers in this assay, from the lowest: compounds 4, 3, 2 and 1 (each within the scatter of the next).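

In this assay, 3,4-dichlorophenyl in place of 3-methylphenyl on a saturated chain carbon, two bonds along the chain from a sulfur, gives a 1.8-fold lower number from compound 2 to compound 4 (0.25 log units; within the scatter). For the compounds shown here, this is the first step read at this position, and the exchange of these two aryl groups does not go beyond the scatter. No measurement at hand bears on the reason for this result. Open, from the compounds shown here alone, is whether a single chlorine, an unsubstituted phenyl or a carboxylic acid on this ring would give a step beyond the scatter. Going by these compounds, a longer chain at this place also remains open.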